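The compounds below may be only part of what the source reports. "The series", "measured", "known", "first", "only" and "open" are said of these compounds alone.

In an ADME assay on HeLa cells (Homo sapiens) for cytotoxicity, with a stated time of 72 h (a higher number here means that more compound is tolerated, a lower number that less compound is tolerated), the two measured compounds stand as follows:

Compound 1 `CC(=O)Nc1ccc(NC(=O)CN2CCN(C)CC2)c(C(=O)c2ccccc2)c1` gives 53000 nM.
Compound 2 `CCC(=O)Nc1ccc(NC(=O)CN2CCN(C)CC2)c(C(=O)c2ccccc2)c1` reaches only a limit of the assay, > 122000 nM.

Compound 2 therefore has no number in this assay, only (the limit of > 122000 nM in this assay, at which 1 of the 2 values shown sits), so its position is known only as that limit. Within the data shown here, the one measured step, an at least 2.3-fold higher number from compound 1 to compound 2 (0.36 log units; beyond the scatter), is an at least modest rise that ends at the limit, and it concerns a different place than the change now at hand. Compound 3 `CN1CCN(CC(=O)Nc2ccc(NC(=O)c3ccccc3)cc2C(=O)c2ccccc2)CC1` differs from compound 2 by phenyl in place of ethyl on a carbonyl carbon. Among the measured compounds shown here, no measured step covers a replacement of this kind, so nothing in the data points to a direction for it. Since compound 2 already stands at the limit, an expected step of an at least 1.1-fold lower number from compound 2 to compound 3 (0.04 log units; that floor lies within the scatter) from compound 2 to compound 3 can hardly be read as a rise; it is estimated to leave compound 3 at or near the same limit, with a fall beyond the scatter possible but unsupported. Compound 3 is therefore expected to show about 110000 nM in this assay, within a range from 40000 nM to 250000 nM.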

Compound 3, half-maximal cytotoxic concentration: > 109000 nM
Compound 3: only a limit was reported; the forecaster's own chance of this, stated with the estimate: 50%; the middle value is on the limit's open side.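

In this assay compound 3 also ends at a limit and not at a number, > 109000 nM. Phenyl in place of methyl on the carbonyl carbon gives an at least 2.0-fold higher number from compound 1 to compound 3 (0.31 log units; beyond the scatter), so on this carbonyl carbon a six-membered aromatic ring of carbon only, like the ethyl of compound 2, goes with a higher number than methyl does. The step from ethyl to phenyl itself cannot be read, because compound 2 too ends at a limit: the limit of > 122000 nM in this assay, at which 1 of the 3 values shown sits.

The compounds shown leave open where the half-maximal cytotoxic concentrations of compound 2 and compound 3 actually lie, and therefore whether ethyl and phenyl differ at all at this position. They also leave open whether a longer chain such as butanoyl, or a phenyl ring carrying an amine or a carboxylic acid, would keep the number at a limit or bring it back towards that of compound 1.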